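Fluoro for hydrogen on the phenyl ring: expected clearance

The source may hold more compounds than are shown below. What is called first, only, known or untested is meant among the compounds shown, and "the series" means these compounds.

Measured compounds:
Compound 1 `COc1cc(NC(C)CCCNC(=O)C2CCC3(CC2)OOC2(OO3)C3CC4CC(C3)CC2C4)c2ncccc2c1-c1ccccc1` gives 33 uL/min in an ADME assay on microsomes from liver (Rattus norvegicus) for metabolic stability, read by HPLC, using NADPH, tested at 1 mM; on this read-out lower numbers stand for slow clearance and higher numbers for fast clearance.
Compound 2 `COc1cc(NC(C)CCCNC(=O)C2CCC3(CC2)OOC2(OO3)C3CC4CC(C3)CC2C4)c2ncccc2c1-c1ccc(C(F)(F)F)cc1` gives 13.9 uL/min in this assay.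
Compound 3 `COc1cc(NC(=O)C2CCC3(CC2)OOC2(OO3)C3CC4CC(C3)CC2C4)c2ncccc2c1-c1ccccc1` gives 33 uL/min in this assay.

Compound 3 stands level with compound 1, and together they show the highest numbers of the three; compound 2 is the lowest. Compound 4 `COc1cc(NC(=O)C2CCC3(CC2)OOC2(OO3)C3CC4CC(C3)CC2C4)c2ncccc2c1-c1ccc(F)cc1` differs from compound 3 by fluoro in place of hydrogen on an aromatic carbon. Within the data shown here, the one related step is a 2.4-fold lower number from compound 1 to compound 2 (0.38 log units; beyond the scatter), where a trifluoromethyl group entered. A fluoro group is smaller, so a smaller shift is expected, and the step of a 1.3-fold lower number from compound 3 to compound 4 (0.12 log units; within the scatter) is expected to stay near the scatter. Compound 4 is therefore estimated at 25 uL/min in this assay, within 14 uL/min to 42 uL/min.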

Compound 4, intrinsic clearance in a liver preparation (reported as CLH), per the amount of preparation that the assay uses: 23.1 uL/min
Compound 4: the middle estimate sits 1.1-fold (0.03 log units) above what was measured, within the range that was stated.
By their numbers in this assay, from the lowest: compounds 2, 4, 1 and 3 (each within the scatter of the next, the first and the last beyond it).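

In this assay, phenyl to 4-fluorophenyl gives a 1.4-fold lower number from compound 3 to compound 4 (0.15 log units; within the scatter), so a single fluoro at this place stays inside the usual scatter. Among these compounds, the only other change on this ring, trifluoromethyl, gave a 2.4-fold lower number from compound 1 to compound 2 (0.38 log units; beyond the scatter), which lies beyond the scatter, though on a different parent compound. No measured evidence here bears on the reason for either result. Going by these compounds, it remains open whether a chlorine atom, a methoxy group or a nitrile at this place would step beyond the scatter, and whether fluoro would read the same on compound 1.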